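A few compounds are considered here, and "the series" means these few. Any claim that something is new, unique, unknown or untested is made for them only; others in the source may bear on it.

Compound 3 `CCOC(=O)c1cc(-c2cccc(OCc3cccc([N+](=O)[O-])c3)c2)on1` carries a nitro group on one of its aromatic rings. In an ADME assay on Vero cells (Chlorocebus sabaeus) for cytotoxicity, with a stated time of 72 h (a higher number here means a weaker inhibitor, a lower number a stronger inhibitor), compound 3 gives > 128000 nM, which is a limit of the assay and not a number. Its two companions stand the same way. Compound 1 `CCOC(=O)c1cc(-c2cccc(OCc3ccccc3)c2)on1` bears hydrogen where compound 3 bears nitro. In this assay compound 1 gives > 128000 nM, again a limit. Compound 2 `CCOC(=O)c1cc(-c2cccc(OCc3cccc(Cl)c3)c2)on1`, which bears chloro at that aromatic carbon, gives in this assay > 128000 nM, also a limit. The three steps among them, a step that the two limits leave unreadable from compound 1 to compound 2, a step that the two limits leave unreadable from compound 1 to compound 3 and a step that the two limits leave unreadable from compound 2 to compound 3, therefore cannot be sized, because of the limit of > 128000 nM in this assay, at which 3 of the 3 values shown sit. Compound 4 `CCOC(=O)c1cc(-c2cccc(OCc3cccc(N)c3)c2)on1` has not yet been measured; it differs from compound 3 by amino in place of nitro on an aromatic carbon. Within the data shown here, none of the measured steps offers a readable size, so no step beyond the scatter is expected in this assay. The step expected from compound 3 to compound 4 is a number no higher from compound 3 to compound 4 (the limit leaves the size open). Compound 4 is accordingly expected to give 128000 nM in this assay, with a range from 50000 nM to 400000 nM, and most likely once more only as a limit.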

Compound 4, half-maximal inhibitory concentration: > 128000 nM
Compound 4 gave a limit, no number; the forecaster's own chance of this, stated with the estimate: 85%; the middle value sits exactly at the limit.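

No step from compound 1, compound 2 or compound 3 to compound 4 can be read in this assay, because the values stop at one limit: the limit of > 128000 nM in this assay, at which 4 of the 4 values shown sit.

The compounds shown leave open whether hydrogen, chloro, nitro and amino differ at all in this read-out.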